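From compound 1 to compound 3: an aryl exchange

The source may report more compounds than this note shows. Statements on the series, on what has been measured and on what is new or still open speak of the compounds shown alone.

In a functional assay on U-251 cells (Homo sapiens) for antiproliferative activity, read by MTT assay, with a stated time of 48 h (a lower number here means a stronger inhibitor, a higher number a weaker inhibitor), compound 1 (`COc1cc(-c2cccc3nc(-c4cccc(Br)c4)oc23)cc(OC)c1OC`) gives 6800 nM and compound 2 (`COc1cc(-c2cccc3nc(-c4cccc(O)c4)oc23)cc(OC)c1OC`) gives 5500 nM. Among the measured compounds shown here, compound 1 holds the higher of only two numbers, but the two lie within the scatter of each other, so it has no distinct rank.

Compound 3 (`COc1cc(-c2cccc3nc(-c4ccc(N)cc4)oc23)cc(OC)c1OC`) has 4-aminophenyl in place of 3-bromophenyl on an aromatic carbon of the five-membered aromatic ring with 1 nitrogen and 1 oxygen: 4-aminophenyl in place of 3-bromophenyl on an aromatic carbon.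

For the measured compounds named here, the only measured step that bears on this exchange is a 1.2-fold lower number from compound 1 to compound 2 (0.09 log units; within the scatter), with hydroxy in place of bromo on an aromatic carbon. Going by the values given here, it gives limited guidance, as no measured compound carries 4-aminophenyl. With that single small step as the precedent, no change beyond the scatter is expected in this assay, although the uncertainty is wide. The expected step is a 1.4-fold lower number from compound 1 to compound 3 (0.13 log units; within the scatter). For compound 3 the estimated value is 5000 nM, with an expected range of 1500 nM to 15000 nM.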

Compound 3, half-maximal inhibitory concentration: 1040 nM
For compound 3 the middle estimate is 4.8-fold (0.68 log units) above the measured one; the measured number lies below the stated range.
By their numbers in this assay, from the lowest: compound 3; then compounds 2 and 1 (each within the scatter of the next).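

In this assay, the aryl group on the aromatic carbon next to the ring nitrogen and next to the ring oxygen can move the number beyond the scatter, which the earlier bromo-to-hydroxy exchange did not show: that exchange gave a 1.2-fold lower number from compound 1 to compound 2 (0.09 log units; within the scatter), whereas the aryl exchange gives a 6.5-fold lower number from compound 1 to compound 3 (0.82 log units; beyond the scatter), a modest gain. The same result appears against the hydroxy compound, with a 5.3-fold lower number from compound 2 to compound 3 (0.72 log units; beyond the scatter), so 4-aminophenyl gives the lowest number of the three, and it does so against both 3-bromophenyl and 3-hydroxyphenyl. Both steps change the substituent and its place on the phenyl ring together, so the gain cannot be assigned to the amino group alone or to the 4-substitution alone.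

The compounds shown leave these two contributions unseparated; 3-aminophenyl and 4-hydroxyphenyl at the same carbon would divide them. They also leave open whether the amine itself matters, which a 4-(dimethylamino)phenyl or 4-acetamidophenyl group would test, and whether the gain extends beyond this single compound. No evidence at hand accounts for the lower number of compound 3.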